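From 3-nitrophenyl to 4-cyanophenyl: working notes on the series

This account rests on a few compounds, and the source may have more. Where it says the series, first, only, none or still open, it means among the compounds named here.

Values so far in a functional assay on MCF7 cells (Homo sapiens) for antiproliferative activity, read by CCK-8 assay, with a stated time of 72 h (a higher number here means a weaker inhibitor, a lower number a stronger inhibitor), are these:
Compound 1 `Cc1cc(Nc2cc(N3CCN(C)CC3)nc(Nc3ccc([N+](=O)[O-])cc3)n2)n[nH]1` gives 424 nM
Compound 2 `Cc1cc(Nc2cc(N3CCN(C)CC3)nc(Nc3cccc([N+](=O)[O-])c3)n2)n[nH]1` gives 642 nM

Compound 2 stands at 642 nM and lies within the scatter of compound 1 at 424 nM in this short series. With only these two values, no order can be read between them.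

Compound 3 `Cc1cc(Nc2cc(N3CCN(C)CC3)nc(Nc3ccc(C#N)cc3)n2)n[nH]1` is not yet measured. Its difference from compound 2 is 4-cyanophenyl in place of 3-nitrophenyl on a nitrogen on an aromatic ring and amounts to 4-cyanophenyl in place of 3-nitrophenyl on a nitrogen on an aromatic ring. Among the compounds with values here, no measured step exchanges a nitro group for a nitrile, so the evidence is indirect and thin. The nearest guide is compound 2 at 642 nM and the step of a 1.5-fold higher number from compound 1 to compound 2 (0.18 log units; within the scatter) at this same place, which stays within the scatter. In this assay no step beyond the scatter is therefore expected, and no direction is favoured. The expected move is a 1.2-fold lower number from compound 2 to compound 3 (0.07 log units; within the scatter) on present evidence. For compound 3 the estimated value is 550 nM with an expected range from 220 nM to 1400 nM on this reading.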

Compound 3, half-maximal inhibitory concentration: 372 nM
Compound 3: middle estimate off by 1.5-fold (0.17 log units), on the high side, within the range that was stated.
By their numbers in this assay, from the lowest: compounds 3, 1 and 2 (each within the scatter of the next).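

In this assay, the series now holds a direct exchange of the two groups on the same ring position, cyano in place of nitro on an aromatic carbon, read as a 1.1-fold lower number from compound 1 to compound 3 (0.06 log units; within the scatter), alongside the change of 4-cyanophenyl in place of 3-nitrophenyl on a nitrogen on an aromatic ring, read as a 1.7-fold lower number from compound 2 to compound 3 (0.24 log units; within the scatter). Both steps stay within the scatter, so a nitro group is not required for a number of this size in this set: the nitrile, with a triple bond in place of the double bond outside the aromatic ring and one hydrogen-bond acceptor fewer by the count for these groups, gives a value that cannot be told apart from those of the two nitro compounds. No measurement of any property of these groups accompanies the values, and the data offer no explanation of the result.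

Every aryl group shown carries a single nitro or nitrile group, so it remains open whether an amine, a carboxylic acid or a plain phenyl at this place would give a number outside the scatter of these three. As far as these compounds go, it also remains open whether a chlorine or a methoxy group would stay within that scatter.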